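A Stereoisomer of Compound 2 Awaits Its Clearance Reading

This account rests on a few compounds, and the source may have more. Where it says the series, first, only, none or still open, it means among the compounds named here.

Compound 1 `CC(O)(c1ccccn1)C1(c2ccc(Cl)c(Cl)c2)CCC1` gives 1670 mL/min/kg
Compound 2 `C[C@]1(O)C[C@](c2ccc(OC(F)(F)F)cc2)([C@H](O)c2ccccn2)C1` gives 50 mL/min/kg
Compound 3 `O[C@H](c1ccccn1)[C@]1(c2ccc(C(F)(F)F)cc2)C[C@@H](O)C1` gives 33.3 mL/min/kg

All three numbers come from an ADME assay on liver for metabolic stability, with Liver microsome (Homo sapiens) as the target, read by LC-MS, using microsomes, with a stated time of 5 h (a higher number here means faster removal of the compound, a lower number slower removal), and are read as clearance. Compound 2 (50 mL/min/kg) lies within the scatter of compound 3 (33.3 mL/min/kg), and both lie far under compound 1 (1670 mL/min/kg).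

The next compound to be measured is compound 4 `C[C@]1(O)C[C@@](c2ccc(OC(F)(F)F)cc2)([C@H](O)c2ccccn2)C1` and the change from compound 2 is confined to its drawing: the two compounds have the same atoms and bonds and differ only in configuration as drawn: 2 of 3 stereo elements differ; a stereocentre at a saturated ring carbon is drawn S in compound 2 and R in compound 4; a stereocentre at a saturated ring carbon is drawn r in compound 2 and s in compound 4. Nothing leaves and nothing enters, since the two compounds have the same atoms and bonds and differ only in configuration as drawn. Within the data shown here, no measured pair here isolates a change of this kind, so the data give neither a size nor a direction for it.

The expectation therefore rests on compound 2 (50 mL/min/kg) alone. The expected step of no change at the digits printed from compound 2 to compound 4 (within the scatter) stays within the scatter, with no direction favoured. In this assay the estimated value for compound 4 is 50 mL/min/kg (expected range 20 mL/min/kg to 130 mL/min/kg).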

Compound 4, clearance: 66.7 mL/min/kg
Estimate against measurement, compound 4: 1.3-fold (0.13 log units) below, within the range that was stated.
By their numbers in this assay, from the lowest: compounds 3, 2 and 4 (each within the scatter of the next); then compound 1.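

Among these compounds, this pair is the first in the set that can be read for a single change, and it can be read cleanly because nothing else separates the two compounds: the fact that compounds 2 and 4 differ only in the configuration as drawn. In this assay the step is a 1.3-fold higher number from compound 2 to compound 4 (0.13 log units; within the scatter), with one stereocentre at a saturated ring carbon going from S to R and another from r to s. The earlier compounds shown here gave this kind of change neither a size nor a direction; this one pair gives it a size that cannot be told apart from repeat measurement.

On these data alone, the third stereo element is drawn alike in both compounds, so what it contributes remains open. Also open, as far as these compounds go, is whether the two configurations would still read alike with an amine in place of the hydroxyl on the saturated ring.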